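The compounds below may be only part of what the source reports. "The series", "measured", "known", "first", "only" and "open" are said of these compounds alone.

Compound 3, `Cc1cccc(Cc2cnc(CCc3ccc(-c4ccccc4C(=O)O)cc3)[nH]2)c1`, is the starting point here. Within the data shown here, in an in vitro functional assay on cells for agonist activity at Bombesin receptor subtype-3 (Homo sapiens), read by luminescence and calcium flux (a higher number here means that more compound is needed for the effect, a lower number that less compound is needed), compound 3 gives 4310 nM, the highest number of the three measured so far, although the distance to compound 2, `CCCCc1cnc(C(CCCC)Cc2ccc(-c3ccccc3C(=O)O)cc2)[nH]1`, which gives 2660 nM, lies within the scatter; only the distance to compound 1, `CCCCc1cnc(C(CCC)Cc2ccc(-c3ccccc3C(=O)O)cc2)[nH]1`, which gives 1180 nM, lies beyond it. Among the measured compounds shown here, the single step measured, a 2.3-fold higher number from compound 1 to compound 2 (0.35 log units; beyond the scatter), sits on the chain of compound 1 and compound 2, and is modest in size.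

Compound 4, `COc1ccccc1Cc1cnc(CCc2ccc(-c3ccccc3C(=O)O)cc2)[nH]1`, is not yet measured. Its change from compound 3 is 2-methoxyphenyl in place of 3-methylphenyl on a saturated chain carbon bound to an aromatic carbon. For the measured compounds named here, no measured step touches this part of the molecule: the one step known alters the saturated chain, not the group on the chain carbon bound to the aromatic carbon. Going by the values given here, there is thus no direct precedent for the exchange, and the expectation is a step of no clear direction, as likely as not within the scatter, so a 1.0-fold lower number from compound 3 to compound 4 (0.00 log units; within the scatter) is the estimated outcome. Compound 4 is therefore expected to give about 4300 nM, with a plausible range from 1800 nM to 10000 nM, pending the measurement.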

Compound 4, half-maximal effective concentration: 1720 nM
For compound 4 the middle estimate is 2.5-fold (0.40 log units) above the measured one, outside the stated range (below it).
By their numbers in this assay, from the lowest: compounds 1, 4, 2 and 3 (each within the scatter of the next, the first and the last beyond it).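

In this assay, the exchange on a saturated chain carbon bound to an aromatic carbon gives a 2.5-fold lower number from compound 3 to compound 4 (0.40 log units; beyond the scatter), a modest step but one beyond the scatter. Among these compounds, this is the first sign that the series responds to the aryl group carried at this place, as the only earlier step lay on the saturated chain. Since 3-methylphenyl and 2-methoxyphenyl differ both in the substituent, methyl against methoxy, and in the number of its position on the ring, this one step cannot separate those two changes, and no supporting measurement is available to explain it.

Still open, going by these compounds, is how 2-methylphenyl, 3-methoxyphenyl or unsubstituted phenyl would read at this place, which would show whether the methoxy group or its position carries the step. Also open, on these data alone, are whether a larger ether such as 2-ethoxyphenyl or a ring containing nitrogen such as pyridyl would extend the step or reverse it, and whether the same exchange would give a similar step on a core bearing a butyl chain.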